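The source may report more compounds than this note shows. Statements on the series, on what has been measured and on what is new or still open speak of the compounds shown alone.

Measured compounds:
compound 1 `O=C(N/N=C\c1ccc(O)cc1)Nc1nnc(COc2ccc3ccccc3c2)o1`, 300 mg/kg
compound 2 `O=C(N/N=C(/c1ccccc1)c1ccc(O)cc1)Nc1nnc(COc2ccc3ccccc3c2)o1`, 300 mg/kg

In a functional assay on the whole organism (strain Wistar) with Rattus norvegicus as the target, with a stated time of 4 h (a higher number here means that more compound is needed for the effect, a lower number that less compound is needed), compound 1 gives 300 mg/kg. In this assay compound 2 gives 300 mg/kg, and the two values stand level at the digits shown, within the scatter of each other, so nothing separates compound 1 from compound 2 on the numbers. Compound 1 therefore stands at the only dose level seen so far.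

Compound 3 `COc1cc(/C=N\NC(=O)Nc2nnc(COc3ccc4ccccc4c3)o2)ccc1O` has not yet been tested in this assay. It differs from compound 1 in one place: methoxy in place of hydrogen on an aromatic carbon. Among the measured compounds shown here, no measured pair shows the effect of this change, so no step can be read from the data; the two measured compounds differ elsewhere and give the same value.

Compound 3 is expected to stay near compound 1, with an estimated step of no change at the digits printed from compound 1 to compound 3 (within the scatter), no larger than the scatter. Compound 3 is estimated at 300 mg/kg, within 150 mg/kg to 600 mg/kg.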

Compound 3, minimum effective dose: 300 mg/kg
For compound 3 middle estimate and measured number coincide at the digits printed; the measured number falls inside the stated range.
By their numbers in this assay, from the lowest: compounds 1, 2 and 3 (each within the scatter of the next).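

In this assay, among the compounds shown here, the change from 4-hydroxyphenyl to 4-hydroxy-3-methoxyphenyl gives no change at the digits printed from compound 1 to compound 3 (within the scatter), the first step that can be read. The earlier compounds shown here offered no reading at this aromatic carbon ortho to a hydroxy group, and it now appears that methoxy can stand here in place of hydrogen without moving the minimum effective dose. Nothing available accounts for this result.

From the compounds shown here alone, it remains open whether a longer chain such as butoxy, or an amine or a carboxylic acid, would leave the dose equally unmoved at this position. Going by these compounds, with all three compounds level, it also remains open which change to the shared core, if any, would separate them in this assay.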